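Shortening the thioester acyl chain in the pyridyl-pyrazole series

The source may hold more compounds than are shown below. What is called first, only, known or untested is meant among the compounds shown, and "the series" means these compounds.

For the measured compounds named here, compound 1 `CCCC(=O)SCCCCCCNC(=O)c1cc(-c2ccncc2)n[nH]1` is the only member of this set with a numerical result: in a functional assay on MCF7 cells (Homo sapiens) for inhibition, read by MTT assay, with a stated time of 96 h (a higher number here means a weaker inhibitor of growth, a lower number a stronger inhibitor of growth), compound 1 gives 12100 nM. Compound 2 `O=C(CCCCCCS)Nc1ccccc1` is an anilide that lacks the shared core of compound 1. In this assay compound 2 returns only the limit > 50000 nM. Going by the values given here, the one thing that can be said of compound 2 is the limit of > 50000 nM in this assay, at which 1 of the 2 values shown sits, so no measured step between compounds exists in this set.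

Compound 3 `CCC(=O)SCCCCCCNC(=O)c1cc(-c2ccncc2)n[nH]1` is the next compound to be run in this assay. It differs from compound 1 as follows: hydrogen in place of methyl on a saturated chain carbon, two bonds along the chain from a carbonyl carbon. The change is one carbon on the acyl side of the thioester, far from the amide and the shared core. A step of a 1.2-fold higher number from compound 1 to compound 3 (0.06 log units; within the scatter) is expected, which is no more than the scatter of the assay. In this assay compound 3 is estimated at 14000 nM, within 6000 nM to 35000 nM.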

Compound 3, concentration for 50% growth inhibition: > 50000 nM
Compound 3: a limit, no number (the forecaster's own chance of this, stated with the estimate: 10%); middle value at least 3.5-fold (0.55 log units) from the limit.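

In this assay compound 3 returns only a limit, > 50000 nM, and not a number. Even so, the one-carbon shortening, propylcarbonyl to propanoyl, gives an at least 4.1-fold higher number from compound 1 to compound 3 (0.61 log units; beyond the scatter), so a change far from the amide and the shared core is enough to move the result beyond the scatter. This position is therefore not indifferent to chain length, though the full size of the step cannot be read, and the limit now accounts for most of the results in this set: the limit of > 50000 nM in this assay, at which 2 of the 3 values shown sit.

On these data alone, whether a longer chain, such as pentanoyl in place of the propylcarbonyl group, would give a lower number than compound 1 stays open. Also open, as far as these compounds go, is whether an acetyl group would stay at the limit, which would show how far the trend with chain length extends.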